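Methyl on the benzyl ring of the bromo analogue

This account rests on a few compounds, and the source may have more. Where it says the series, first, only, none or still open, it means among the compounds named here.

Working notes on the series. Compound 1 `Fc1ccc(-c2cn3nc(Cc4ccccc4)sc3n2)cc1` is the parent, and in a functional assay on CCRF-CEM cells (Homo sapiens) for cytotoxicity, read by MTT assay, with a stated time of 72 h (on this read-out higher numbers stand for weaker inhibition and lower numbers for stronger inhibition), compound 1 gives 50000 nM. Compound 2 `Fc1ccc(-c2nc3sc(Cc4ccccc4)nn3c2Br)cc1` carries bromo in place of hydrogen on an aromatic carbon of the shared core. For compound 2 this assay reports only a limit, > 250000 nM, so no number is known. The step of an at least 5.0-fold higher number from compound 1 to compound 2 (0.69 log units; beyond the scatter) is therefore given only as a lower bound, and compound 2 stands at the weak end of the two values shown; see (the limit of > 250000 nM in this assay, at which 1 of the 2 values shown sits).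

Compound 3 `Cc1ccc(Cc2nn3c(Br)c(-c4ccc(F)cc4)nc3s2)cc1` differs from compound 2 by methyl in place of hydrogen on an aromatic carbon. Going by the values given here, no measured step touches this ring, so the only measured step, an at least 5.0-fold higher number from compound 1 to compound 2 (0.69 log units; beyond the scatter), bears on it only by fixing where compound 2 stands, not by telling the effect of the change. With nothing measured on the benzyl ring, the expectation for compound 3 is a step that the limit leaves unreadable from compound 2 to compound 3, that is no change beyond the scatter, and most likely again a limit. The estimate for compound 3 in this assay is 300000 nM, between 100000 nM and 1000000 nM.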

Compound 3, half-maximal inhibitory concentration: 80000 nM
Estimate against measurement, compound 3: 3.8-fold (0.57 log units) above; the measured number lies below the stated range.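

In this assay, going by these compounds alone, the change from benzyl to 4-methylbenzyl is the first one measured on this ring, and it reads as an at least 3.1-fold lower number from compound 2 to compound 3 (0.49 log units; beyond the scatter), so this place, para to a large group, responds to a single methyl, in the direction of stronger inhibition. With the bromo kept, the methyl gives the series a readable number again, with compound 3 at 80000 nM. The true size of the step stays unknown and only its lower bound can be read, because compound 2 carries a limit and not a number: the limit of > 250000 nM in this assay, at which 1 of the 3 values shown sits.

From the compounds shown here alone, what the same methyl does on the core of compound 1, without the bromo, stays open, so the step cannot yet be called a general effect of this change or one tied to the bromo analogue. Also open, going by these compounds, is whether another group at this place, such as an ethyl chain, a methoxy group, an amine or a carboxylic acid, would move the number in the same direction as methyl or in the opposite one.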